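Nitro on the benzamide ring: compound 3 from compound 1

The compounds below may be only part of what the source reports. "The series", "measured", "known", "first", "only" and "open" are said of these compounds alone.

Compound 1: `N#CC1=C(NC(=O)c2ccccc2)N(c2ccc(S(N)(=O)=O)cc2)C2=C(C(=O)CCC2)C1c1ccc(Cl)cc1Cl` — 50%
Compound 2: `Cc1ccc(C(=O)NC2=C(C#N)C(c3ccc(Cl)cc3Cl)C3=C(CCCC3=O)N2c2ccc(S(N)(=O)=O)cc2)cc1` — 20%

In a functional assay on Ehrlich cells (Mus musculus) for cytotoxicity, read by trypan blue exclusion, with a stated time of 2 h, tested at 10 ug/mL (a higher number here means a stronger effect of the compound at the concentration tested, a lower number a weaker effect), compound 1 gives 50%, the higher of the two numbers measured; compound 2, the nearest neighbour, gives 20%. Among the compounds with values here, the one step measured so far, a number 30 percentage points lower from compound 1 to compound 2 (beyond the scatter), arose from a methyl in place of hydrogen on an aromatic carbon of the benzamide ring.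

Compound 3, `N#CC1=C(NC(=O)c2ccc([N+](=O)[O-])cc2)N(c2ccc(S(N)(=O)=O)cc2)C2=C(C(=O)CCC2)C1c1ccc(Cl)cc1Cl`, differs from compound 1 by nitro in place of hydrogen on an aromatic carbon. The change sits on the same ring as the change from compound 1 to compound 2, and that step was modest and downward. A nitro group is not a methyl group, so this step bears on compound 3 only by position; the data give no closer guide. A downward step of similar size in this assay is therefore expected, though a weaker or stronger outcome cannot be excluded. For compound 3 the estimate is 30%, within 10% to 60%, which would be a step of a number 20 percentage points lower from compound 1 to compound 3 (beyond the scatter).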

Compound 3, a percentage reported as activity, at one concentration (the size of the read-out at that concentration, not a potency): 40%
For compound 3 the middle estimate is 10 percentage points below the measured one; measured number inside the range.
By their numbers in this assay, from the lowest: compound 2; then compounds 3 and 1 (each within the scatter of the next).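

Nitro in place of hydrogen on the benzamido ring gives a number 10 percentage points lower from compound 1 to compound 3 (within the scatter) in this assay, so the clear loss seen with methyl on this ring is not shared by every group placed at this carbon. Exchanging one group for the other at the same carbon gives a number 20 percentage points higher from compound 2 to compound 3 (beyond the scatter), which shows that the read-out here depends on which group enters and not merely on hydrogen being replaced. Nothing available explains why the two groups differ. The compounds shown leave open how an amine, a carboxylic acid or a methoxy group would read at this carbon. They also leave open how these compounds would compare across a range of concentrations, since each has a read-out at one concentration only.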